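A cyclopropylmethyl replacement in a cytotoxicity series

This account rests on a few compounds, and the source may have more. Where it says the series, first, only, none or still open, it means among the compounds named here.

Compound 1 `COc1cc2c(=O)c(C(=O)c3ccc(C)cc3)cn(Cc3ccc(S(N)(=O)=O)cc3)c2cc1OC` was tested in an ADME assay on Huh-7 cells (Homo sapiens) for cytotoxicity; a lower number here means a stronger inhibitor of growth, a higher number a weaker inhibitor of growth. Compound 1 gives > 25000 nM in this assay, which is a limit of the assay and not a number. Compound 2 `CN1CCN(c2cc3c(cc2F)c(=O)c(NC(=O)NCc2ccc(Cl)cc2)cn3Cc2ccc(Cl)cc2)CC1` is recorded in this assay as "not active" (no number reported). Compound 3 `CN1CCN(c2cc3c(cc2F)c(=O)c(NC(=O)NCc2ccccc2)cn3Cc2ccccc2)CC1` is recorded in this assay as "not active" (no number reported). Going by the values given here, no step between measured compounds can be drawn, so compound 1 stands only at the limit of > 25000 nM in this assay, at which 1 of the 3 values shown sits. Compound 4 `COc1cc2c(=O)c(C(=O)c3ccc(C)cc3)cn(CC3CC3)c2cc1OC` differs from compound 1 by cyclopropyl in place of 4-sulfamoylphenyl on a saturated chain carbon bound to an aromatic nitrogen. Among the compounds with values here, with no measured step to lean on, the expected step that the limit leaves unreadable from compound 1 to compound 4 is none beyond the scatter, and the assay is expected to return again only a limit. Compound 4 is estimated at 30000 nM in this assay, with a range from 10000 nM to 100000 nM.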

Compound 4, concentration for 50% growth inhibition: "not active" (no number reported)
Compound 4 has no reported number here, and the estimate cannot be compared.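

Going by these compounds alone, compound 4 carries no number in this assay and compound 1 stands only at a limit, so no step between compound 1 and compound 4 can be read. The compounds shown leave open what replacing 4-sulfamoylbenzyl with cyclopropylmethyl does in this assay.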